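A few compounds are considered here, and "the series" means these few. Any claim that something is new, unique, unknown or untested is made for them only; others in the source may bear on it.

Measured in an ADME assay on a cell-free system (plasma, Homo sapiens) for protein binding, with Plasma (Rattus norvegicus) as the target:
- compound 1 `O=C(O)c1cn(Cc2ccc(-n3cccn3)cc2)c2cccc(F)c2c1=O` gives 89.8% 
- compound 2 `O=C(O)c1cn(Cc2ccc(-n3ccnc3)cc2)c2cccc(F)c2c1=O` gives 88.1% 

These two values show no real separation, so compound 1 stands level with compound 2 at high binding. Among the measured compounds shown here, the only measured step is a 1.2-fold higher unbound fraction from compound 1 to compound 2 (0.07 log units; within the scatter) on exchanging 1H-pyrazol-1-yl for 1H-imidazol-1-yl.

Compound 3 `O=C(O)c1cn(Cc2ccc(-n3cccn3)cc2)c2c(F)ccc(F)c2c1=O` differs from compound 1 by one change, (fluoro in place of hydrogen on an aromatic carbon), with fluoro in place of hydrogen on an aromatic carbon, para to a fluoro group. For the measured compounds named here, the measured step lies at another place, so it gives only a sense of scale, and no measured step covers this change. In this assay no shift beyond the scatter is expected, with a slight lean towards less free compound. The expected step is a 1.1-fold lower unbound fraction from compound 1 to compound 3 (0.05 log units; within the scatter) as a working estimate. For compound 3 the estimated value is 91% (expected range 84% to 95.5%).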

Compound 3, plasma protein binding: 94.9%
Compound 3: the middle estimate sits 1.8-fold (0.25 log units) (unbound fraction) above what was measured; the range from low to high includes it.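

In this assay, fluoro in place of hydrogen on this aromatic carbon, para to a fluoro group, gives a 2.0-fold lower unbound fraction from compound 1 to compound 3 (0.30 log units; within the scatter) and so stays within the scatter. Among the compounds shown here, this is the first reading at this position on the shared core, as the earlier pair differed only in 1H-pyrazol-1-yl versus 1H-imidazol-1-yl, and it shows that the added fluoro leaves compound 3 in the same high-binding range without a shift that can be claimed. No measured information is available to explain this result.

Still open, on these data alone, is whether the same fluoro change on the core of compound 2 would read alike. Also open, as far as these compounds go, is whether a larger group at this position, such as a methoxy group or an amine, would move binding beyond the scatter.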